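The compounds below may be only part of what the source reports. "The series", "measured", "known", "first", "only" and "open" are said of these compounds alone.

In a functional assay on HepG2 cells (Homo sapiens) for cytotoxicity, read by sulforhodamine B assay, with a stated time of 48 h (a higher number here means a weaker inhibitor, a lower number a stronger inhibitor), compound 1 `SC1=NNCC(n2c(-c3ccco3)nc3ccccc32)=N1` gives 62100 nM. Compound 2 `NNC(=O)CSc1nnc(Cn2c(-c3ccco3)nc3ccccc32)s1` gives 26900 nM, the lower of these two numbers, and the gap between them lies beyond the usual scatter. Compound 3 `CCOC(=O)CSc1nnc(Cn2c(-c3ccco3)nc3ccccc32)s1` has not yet been measured. It differs from compound 2 in one place, with ethoxy in place of aminoamino on a carbonyl carbon, so that aminocarbamoyl becomes ethoxycarbonyl. Among the measured compounds shown here, no two measured compounds differ by this change alone, so the best available guide is compound 2 itself, at 26900 nM. The a 1.1-fold higher number from compound 2 to compound 3 (0.05 log units; within the scatter) is therefore expected to be small, within the usual scatter, and its direction is uncertain. For compound 3 the estimated value is 30000 nM, with an expected range from 11000 nM to 80000 nM.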

Compound 3, half-maximal inhibitory concentration: 62100 nM
For compound 3 the middle estimate is 2.1-fold (0.32 log units) below the measured one, and the stated range covers the measured number.
By their numbers in this assay, from the lowest: compound 2; then compounds 1 and 3 (each within the scatter of the next).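

In this assay, among the compounds shown here, the swap of aminoamino for ethoxy on this carbonyl carbon gives a 2.3-fold higher number from compound 2 to compound 3 (0.36 log units; beyond the scatter), the first change in the set that can be read on its own. It shows that the end of the ((aminocarbamoyl)methyl)sulfanyl chain is not a silent spot: replacing aminocarbamoyl with ethoxycarbonyl, which takes away the hydrogen-bond donors of aminoamino, moves the number modestly towards a weaker inhibitor. Nothing measured here bears on why the number changes.

On these data alone, with a single swap at this place, it remains open whether the step follows from losing aminoamino or from bringing in ethoxy. A carboxylic acid, a simple primary amide or a longer ester chain at the same carbonyl carbon could help separate the two.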